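This account rests on a few compounds, and the source may have more. Where it says the series, first, only, none or still open, it means among the compounds named here.

Measured so far in an ADME assay on MDBK cells (Bos taurus) for cytotoxicity, read by MTT assay, with a stated time of 96 h; on this read-out higher numbers stand for lower toxicity in this test and lower numbers for higher toxicity in this test: compound 1 `COc1ccc(-c2nc3cc(C(C)=O)ccc3[nH]2)c(OC)c1` gives 73000 nM, and compound 3 `COc1ccc(-c2nc3cc(/C(C)=N/NC(N)=O)ccc3[nH]2)cc1` gives 25000 nM. Compound 2 `COc1ccc(-c2nc3cc(C(C)=O)ccc3[nH]2)c(OC)c1OC` reaches only a limit of this assay, > 100000 nM.

Compound 1 and compound 2 differ in one place: methoxy in place of hydrogen on an aromatic carbon. This change gave an at least 1.3-fold higher number from compound 1 to compound 2 (0.13 log units; that floor lies within the scatter). The floor of that step is set by the limit described in the limit of > 100000 nM in this assay, at which 1 of the 3 values shown sits, so the true size of the step is not known. Between compound 3 and compound 1 the difference between the two cores is not broken down here; what their values show is that compound 3 gives the lower number in this assay, and that gap lies beyond the scatter.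

Compound 4 `COc1ccc(-c2nc3cc(/C(C)=N/NC(N)=O)ccc3[nH]2)c(OC)c1` has not yet been measured in this assay. It differs from compound 3 by methoxy in place of hydrogen on an aromatic carbon. This is the same kind of change as that from compound 1 to compound 2, though not the same: in compound 4 the new methoxy sits ortho to a large group and meta to a methoxy group, whereas in compound 2 it sits ortho to two methoxy groups and meta to a large group.

The expectation for compound 4 rests mainly on compound 3 at 25000 nM and on the direction of an at least 1.3-fold higher number from compound 1 to compound 2 (0.13 log units; that floor lies within the scatter); the true size of that earlier step is not known. The step from compound 3 to compound 4 is expected to be small, about a 1.4-fold higher number from compound 3 to compound 4 (0.15 log units; within the scatter). Compound 4 is therefore estimated at 35000 nM, with a range from 15000 nM to 85000 nM.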

Compound 4, half-maximal cytotoxic concentration: > 100000 nM
Compound 4: only a limit was reported; the forecaster's own chance of this, stated with the estimate: 10%; at least 2.8-fold (0.45 log units) between middle value and limit.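

Placed on the core of compound 3, methoxy in place of hydrogen on an aromatic carbon gives an at least 4.0-fold higher number from compound 3 to compound 4 (0.60 log units; beyond the scatter), so on this core the change goes with lower toxicity in this test in this assay. On the core of compound 1 the same kind of change points the same way, but its floor does not clear the scatter, and the two steps cannot be ranked against each other: the same change on two cores in this assay, an at least 1.3-fold higher number (0.13 log units; that floor lies within the scatter) from compound 1 to compound 2 and an at least 4.0-fold higher number (0.60 log units; beyond the scatter) from compound 3 to compound 4; the limit leaves it open whether they differ Neither step has a known true size, and the new methoxy sits in a different place on the two cores, so these two pairs do not show that the change carries over from one core to another by a fixed amount: the limit of > 100000 nM in this assay, at which 2 of the 4 values shown sit.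

The exchange of the side group on the shared core, read with the new methoxy in place, gives an at least 1.3-fold higher number from compound 1 to compound 4 (0.13 log units; that floor lies within the scatter), and this is again only a floor that leaves the true size of the step open. The compounds shown also leave open how an ethoxy group, a hydroxyl group or an amine on the same aromatic carbon would read, and whether any of them would stay clear of the limit of this assay.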